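A few compounds are considered here, and "the series" means these few. Any claim that something is new, unique, unknown or untested is made for them only; others in the source may bear on it.

Measured in a functional assay on QGY7701 cells (Homo sapiens) for cytotoxicity, read by MTT assay, with a stated time of 24 h; a lower number here means a stronger inhibitor, a higher number a weaker inhibitor:
compound 1 `C=CC1=C(C(=O)NCCCCC)C(c2ccc(Cl)c(Cl)c2)OC1` — > 100000 nM, a limit
compound 2 `C=CC1=C(C(=O)NCCC)C(c2ccc(Cl)c(Cl)c2)OC1` — 31300 nM
compound 3 `C=CC1=C(C(=O)NC(C)(C)C)C(c2ccc(Cl)c(Cl)c2)OC1` — > 100000 nM, a limit

Compound 3 stands at the limit of > 100000 nM in this assay, at which 2 of the 3 values shown sit. Compound 4 `C=CC1=C(C(=O)O)C(c2ccc(Cl)c(Cl)c2)OC1` differs from compound 3 by hydroxy in place of (tert-butyl)amino on a carbonyl carbon. Going by the values given here, no measured step changes the carbonyl substituent in this way; the nearest ones, an at least 3.1-fold higher number from compound 2 to compound 3 (0.50 log units; beyond the scatter) and an at least 3.1-fold lower number from compound 1 to compound 2 (0.50 log units; beyond the scatter), only vary the group on the amide nitrogen, and they show that the series moves between the low value of compound 2 and the limit. Because compound 3 already sits at the limit of > 100000 nM in this assay, at which 2 of the 3 values shown sit, the expected step of a number no higher from compound 3 to compound 4 (the limit leaves the size open) is none readable beyond the scatter. Compound 4 is expected at 100000 nM, with a range from 30000 nM to 300000 nM, and most likely reported as a limit.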

Compound 4, half-maximal inhibitory concentration: > 100000 nM
Compound 4 ended at the assay's limit; the forecaster's own chance of this, stated with the estimate: 65%; the middle value lies on the limit itself.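

With hydroxy on a carbonyl carbon, compound 4 gives > 100000 nM in this assay as a limit of the assay. Going by these compounds alone, replacing propylamino with hydroxy gives an at least 3.1-fold higher number from compound 2 to compound 4 (0.50 log units; beyond the scatter) and leaves compound 2 as the only compound here with a value that is not a limit. The steps from compound 1 and compound 3 to compound 4 cannot be read, and the free acid joins the bulkier and longer amides at the same end of the series: the limit of > 100000 nM in this assay, at which 3 of the 4 values shown sit.

Still open, from the compounds shown here alone, is whether a methyl ester or a primary amide on this carbonyl carbon gives a value that is not a limit. An ethyl or butyl chain on the amide nitrogen would show how narrow the window around propyl is.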